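The source may hold more compounds than are shown below. What is called first, only, known or untested is meant among the compounds shown, and "the series" means these compounds.

Compound 1, `O=C(O)CCCOc1ccc(OCc2ccc3ccccc3n2)cc1`: 1200 nM
Compound 2, `O=C(O)CCC(Cc1cccc(OCc2ccc3ccccc3n2)c1)c1ccccc1`: 52 nM
Compound 3, `CCCC(CCc1nnn[nH]1)Cc1cccc(OCc2ccc3ccccc3n2)c1`: 11 nM

Of the compounds shown here, three sharing a common core have been tested in an assay on membranes from lung (Cavia porcellus) for binding affinity to cysteinyl leukotriene receptor (Homo sapiens); a higher number here means a weaker inhibitor, a lower number a stronger inhibitor. Compound 1 gives 1200 nM, the highest of the three numbers, so it is the weakest inhibitor of the group. Compound 2 gives 52 nM and compound 3 gives 11 nM; both lie far below compound 1, well beyond the usual scatter. Compound 2 and compound 3 each differ from compound 1 in more than one place, so neither gap can be assigned to a single structural change.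

Compound 4, `O=C(O)C1CCC(c2ccc(OCc3ccc4ccccc4n3)cc2)C1`, has not yet been measured. It differs from compound 1 in one place only: 3-carboxycyclopentyl in place of 3-carboxypropoxy on an aromatic carbon. The acid group thus sits on a ring instead of at the end of a flexible chain. For the measured compounds named here, no measured pair shows this kind of change, so there is no direct precedent for its effect. A small step toward a lower number is expected, of a size that may not exceed the scatter: the expected step from compound 1 to compound 4 is a 1.7-fold lower number from compound 1 to compound 4 (0.23 log units; within the scatter). In this assay compound 4 is estimated at 700 nM, with a plausible range from 200 nM to 2500 nM.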

Compound 4, inhibition constant: 43 nM
Beside the measured number, compound 4's estimate is 16-fold (1.21 log units) above it; the whole stated range lies above it.
By their numbers in this assay, from the lowest: compound 3; then compounds 4 and 2 (each within the scatter of the next); then compound 1.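

In this assay, the aromatic carbon para to a large group proves highly sensitive to what carries the acid: 3-carboxycyclopentyl in place of 3-carboxypropoxy gives a 28-fold lower number from compound 1 to compound 4 (1.45 log units; beyond the scatter). This is the only change among the compounds shown that can be read on its own, and it shows that a carboxylic acid held on a five-membered carbon ring can be far stronger here than one at the end of an open chain joined through oxygen. Nothing available explains the size of this step.

For the compounds shown here, the single change adds the ring and removes the oxygen link together, so their separate contributions remain unknown. A 4-carboxybutyl group, an open chain joined through carbon, at this same place would tell the two apart.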